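This account rests on a few compounds, and the source may have more. Where it says the series, first, only, none or still open, it means among the compounds named here.

Of the compounds shown here, three on one shared core have numbers so far in a functional assay on MCF7 cells (Homo sapiens) for cytotoxicity, read by MTT assay, with a stated time of 96 h; a higher number here means a weaker inhibitor, a lower number a stronger inhibitor. Compound 1 `COc1cc(C(=O)c2cn(-c3cccc(Cl)c3)cc2-c2ccccc2)cc(OC)c1OC` gives 150 nM and compound 2 `COc1cc(C(=O)c2cn(-c3cccc([N+](=O)[O-])c3)cc2-c2ccccc2)cc(OC)c1OC` gives 550 nM in this assay. Compound 3 `COc1cc(C(=O)c2cn(-c3ccc(Cl)cc3)cc2-c2ccccc2)cc(OC)c1OC` gives 140 nM and stands level with compound 1 within the scatter (a 1.1-fold lower number from compound 1 to compound 3 (0.03 log units; within the scatter)), while its gap to the third compound is beyond the scatter (a 3.9-fold lower number from compound 2 to compound 3 (0.59 log units; beyond the scatter)). Compound 4 `COc1cc(C(=O)c2cn(-c3ccc([N+](=O)[O-])cc3)cc2-c2ccccc2)cc(OC)c1OC` differs from compound 3 by one change (nitro in place of chloro on an aromatic carbon): 4-chlorophenyl to 4-nitrophenyl, para to a large group. The same exchange of nitro in place of chloro has been seen once, as a modest step to a higher number (a 3.7-fold higher number from compound 1 to compound 2 (0.56 log units; beyond the scatter)). A step of similar size and direction is therefore expected in this assay (a 3.6-fold higher number from compound 3 to compound 4 (0.55 log units; beyond the scatter)). Compound 4 is estimated at 500 nM (expected range 220 nM to 1100 nM).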

Compound 4, half-maximal inhibitory concentration: 4000 nM
Compound 4: middle estimate off by 8.0-fold (0.90 log units), on the low side; measured number outside the range, above it.
By their numbers in this assay, from the lowest: compounds 3 and 1 (each within the scatter of the next); then compound 2; then compound 4.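

In this assay, nitro in place of chloro does not carry one fixed cost, as the same exchange gives clearly different steps in the two places on the ring: the same change on two cores in this assay, a 3.7-fold higher number (0.56 log units; beyond the scatter) from compound 1 to compound 2 and a 29-fold higher number (1.46 log units; beyond the scatter) from compound 3 to compound 4, 7.8-fold (0.89 log units) apart, beyond the scatter of two such steps. The 4-nitrophenyl group stands apart from both chloro compounds, with a 29-fold higher number from compound 3 to compound 4 (1.46 log units; beyond the scatter) and a 27-fold higher number from compound 1 to compound 4 (1.43 log units; beyond the scatter). Among the nitro compounds the place of the group matters, with a 7.3-fold higher number from compound 2 to compound 4 (0.86 log units; beyond the scatter), while among the chloro compounds the numbers stay level, with a 1.1-fold lower number from compound 1 to compound 3 (0.03 log units; within the scatter).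

The compounds shown do not tell why the nitro compounds respond so differently to the move. They also leave open whether an amine or a carboxylic acid in the same places would follow nitro or chloro.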